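Replacing Chloro with 4-(pyrrolidin-1-yl)piperidin-1-yl

This account rests on a few compounds, and the source may have more. Where it says the series, first, only, none or still open, it means among the compounds named here.

In a functional assay on LNCaP cells (Homo sapiens) for antiproliferative activity, read by MTT assay, with a stated time of 96 h (on this read-out lower numbers stand for stronger inhibition and higher numbers for weaker inhibition), compound 3 (`FC(F)(F)Oc1cccc(Nc2nnnc3ccc(Cl)nc23)c1`) gives 8620 nM as its result, and compound 2 (`FC(F)(F)Oc1cccc(Nc2nnnc3ccc(N4CCC(N5CCCCC5)CC4)nc23)c1`) gives 4900 nM as its own, two values within the scatter of each other. Compound 1 (`FC(F)(F)Oc1cccc(Nc2nnnc3ccc(N4CCCC4)nc23)c1`) is reported only as a limit, > 100000 nM in this assay, and so has no exact number.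

Going on to compound 4 (`FC(F)(F)Oc1cccc(Nc2nnnc3ccc(N4CCC(N5CCCC5)CC4)nc23)c1`) puts 4-(pyrrolidin-1-yl)piperidin-1-yl in place of chloro on an aromatic carbon, next to the ring nitrogen (4-(pyrrolidin-1-yl)piperidin-1-yl in place of chloro on an aromatic carbon). Within the data shown here, one measured step bears on this change: an at least 11-fold lower number from compound 1 to compound 3 (1.06 log units; beyond the scatter) is large, but it concerns pyrrolidin-1-yl and not the group entering here. The closer guide is compound 2 with 4900 nM for its similar amine at that place, so no step beyond the scatter is expected in this assay for this change. The expected step is a 1.7-fold lower number from compound 3 to compound 4 (0.24 log units; within the scatter) and remains an estimate. Estimated for compound 4 in this assay is 5000 nM, with 1800 nM to 14000 nM as the expected range.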

Compound 4, half-maximal inhibitory concentration: 10700 nM
Beside the measured number, compound 4's estimate is 2.1-fold (0.33 log units) below it; low and high end bracket the measured number.
By their numbers in this assay, from the lowest: compounds 2, 3 and 4 (each within the scatter of the next, the first and the last beyond it). At a limit, above all of these: compound 1.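

In this assay, 4-(pyrrolidin-1-yl)piperidin-1-yl on this aromatic carbon reads the same as chloro, with a 1.2-fold higher number from compound 3 to compound 4 (0.09 log units; within the scatter). The outer ring on the saturated ring carbon does count, if modestly: pyrrolidin-1-yl in place of piperidin-1-yl gives a 2.2-fold higher number from compound 2 to compound 4 (0.34 log units; beyond the scatter), so the number here responds to the far end of the entering group as well as to the atom attached to the aromatic carbon. Against pyrrolidin-1-yl alone on the aromatic carbon, the entering group gives an at least 9.3-fold lower number from compound 1 to compound 4 (0.97 log units; beyond the scatter), a step that rests on a limit and not on an exact number: the limit of > 100000 nM in this assay, at which 1 of the 4 values shown sits.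

As far as these compounds go, whether the outer ring's nitrogen is needed remains open. A morpholin-4-yl or 4-hydroxypiperidin-1-yl group at this place, or a dimethylamino group on the saturated ring carbon, would bear on that question.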